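The source may hold more compounds than are shown below. What is called first, only, known or untested is meant among the compounds shown, and "the series" means these compounds.

In an ADME assay on HepG2 cells (Homo sapiens) for inhibition, read by fluorescence and resazurin assay, with a stated time of 72 h (on this read-out lower numbers stand for stronger inhibition and higher numbers for weaker inhibition), compound 1 `NC(=O)c1ccc(Nc2nccc(Nc3ccc4cn[nH]c4c3)n2)cc1` gives 16000 nM and compound 2 `Brc1ccc(Nc2nccc(Nc3ccc4cn[nH]c4c3)n2)cc1` gives 20000 nM, so compound 2 stands level with compound 1 within the scatter. Compound 3 `CN1CCN(c2ccc(Nc3nccc(Nc4ccc5cn[nH]c5c4)n3)cc2)CC1` has 4-methylpiperazin-1-yl in place of bromo on an aromatic carbon. Going by the values given here, only one measured step bears on this place, a 1.3-fold higher number from compound 1 to compound 2 (0.10 log units; within the scatter), and it stays within the scatter. No step beyond the scatter is therefore expected in this assay, though a single step leaves the range wide. The expected step is a 1.7-fold lower number from compound 2 to compound 3 (0.22 log units; within the scatter). The estimate for compound 3 is 12000 nM, with an expected range of 3000 nM to 35000 nM.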

Compound 3, half-maximal inhibitory concentration: 7000 nM
Beside the measured number, compound 3's estimate is 1.7-fold (0.23 log units) above it; the measured number falls inside the stated range.
By their numbers in this assay, from the lowest: compound 3; then compounds 1 and 2 (each within the scatter of the next).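

At this aromatic carbon, para to a large group, bromo and carbamoyl left this assay within the scatter, whereas 4-methylpiperazin-1-yl gives a modest step beyond it, seen against both groups (a 2.9-fold lower number from compound 2 to compound 3 (0.46 log units; beyond the scatter); a 2.3-fold lower number from compound 1 to compound 3 (0.36 log units; beyond the scatter)). The position therefore responds to at least this change, though the size of the step stays small. No measured evidence accounts for the step. Open, from the compounds shown here alone, is whether the step needs the whole 4-methylpiperazin-1-yl group; a morpholine or an unsubstituted piperazine at this carbon would bear on that.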